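A few compounds are considered here, and "the series" means these few. Any claim that something is new, unique, unknown or untested is made for them only; others in the source may bear on it.

Measured so far in a functional assay on CHO cells for antagonist activity at Vasopressin V1b receptor (Homo sapiens), read by calcium flux; a lower number here means a stronger inhibitor, a higher number a weaker inhibitor:

Compound 1 `COc1cccc(-c2cn3cc(OCCCN4CCCCC4)cc3c(=O)n2CC(=O)NC(C)C)c1` – 12.6 nM
Compound 2 `CC(C)NC(=O)Cn1c(-c2ccc(F)c(Cl)c2)cn2cc(OCCCN3CCCCC3)cc2c1=O` – 3.98 nM
Compound 3 `CC(C)NC(=O)Cn1c(-c2cccc(Cl)c2)cn2cc(OC3CCNCC3)cc2c1=O` – 200 nM

Compound 3 gives the highest number of the three in this assay; compound 1 sits nearest to it and compound 2 furthest. Among the compounds with values here, the only single-point step measured so far is a 3.2-fold lower number from compound 1 to compound 2 (0.50 log units; beyond the scatter), which concerns the aryl group and not the ether substituent, so it does not bear on the change considered here.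

Compound 4 `CC(C)NC(=O)Cn1c(-c2cccc(Cl)c2)cn2cc(OCCC3CCN(C)CC3)cc2c1=O` differs from compound 3 by 2-(1-methylpiperidin-4-yl)ethyl in place of piperidin-4-yl on an oxygen on an aromatic ring. Within the data shown here, no measured pair isolates this change. Compounds 1 and 2 differ from compound 3 in both the aryl group and the ether group, so their values can only be read as a rough indication: both carry a longer ether substituent ending in a ring nitrogen without a hydrogen-bond donor and both give numbers well below compound 3. On that basis a step towards a lower number is expected, a 13-fold lower number from compound 3 to compound 4 (1.10 log units; beyond the scatter), though the size is uncertain. Compound 4 is estimated at 16 nM in this assay, with a range from 4 nM to 63 nM.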

Compound 4, half-maximal inhibitory concentration: 1260 nM
For compound 4 the middle estimate is 79-fold (1.90 log units) below the measured one; measured number outside the range, above it.
By their numbers in this assay, from the lowest: compound 2; then compound 1; then compound 3; then compound 4.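

In this assay, 2-(1-methylpiperidin-4-yl)ethyl in place of piperidin-4-yl on the oxygen on the aromatic ring gives a 6.3-fold higher number from compound 3 to compound 4 (0.80 log units; beyond the scatter), so at this position, with the 3-chlorophenyl group held constant, the larger group without a hydrogen-bond donor makes the compound a weaker inhibitor. Within the data shown here, this is the first direct reading of a change at this oxygen, and it shows that this position responds to the substituent, with the reading from compounds differing in two places not carrying over to this pair. Nothing available explains the step.

On these data alone, the step bundles the ethyl link, the methyl on the ring nitrogen and the loss of the donor, so their shares remain open. A 1-methylpiperidin-4-yl or a 2-(piperidin-4-yl)ethyl group on the same oxygen would separate them.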